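Oxime Methylation and Nitro-to-Amino Exchange on a Shared Core

This account rests on a few compounds, and the source may have more. Where it says the series, first, only, none or still open, it means among the compounds named here.

Measured compounds:
compound 1 `COc1ccc(-c2c(-c3cc(OC)c(OC)c(OC)c3)ss/c2=N/O)cc1[N+](=O)[O-]`: 5260 nM
compound 2 `COc1ccc(-c2c(-c3cc(OC)c(OC)c(OC)c3)ss/c2=N/O)cc1N`: 2910 nM
compound 3 `CO/N=c1/ssc(-c2cc(OC)c(OC)c(OC)c2)c1-c1ccc(OC)c([N+](=O)[O-])c1`: > 100000 nM

Three compounds were tested in a functional assay on KB cells (Homo sapiens) for antiproliferative activity, read by MTT assay, with a stated time of 72 h; a higher number here means a weaker inhibitor, a lower number a stronger inhibitor. Compound 1 gives 5260 nM, and compound 2 gives 2910 nM. The change between them, (amino in place of nitro on an aromatic carbon), made the step of a 1.8-fold lower number from compound 1 to compound 2 (0.26 log units; within the scatter). For compound 3 the assay reported only a limit, > 100000 nM. The two cores differ by methyl in place of hydrogen on an oxygen, and the step of an at least 19-fold higher number from compound 1 to compound 3 (1.27 log units; beyond the scatter) is large; compound 3 sits at the limit of > 100000 nM in this assay, at which 1 of the 3 values shown sits.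

Compound 4 `CO/N=c1/ssc(-c2cc(OC)c(OC)c(OC)c2)c1-c1ccc(OC)c(N)c1` has not been measured. It differs from compound 3 by amino in place of nitro on an aromatic carbon, the same change as between compound 1 and compound 2, at an identical place. In this assay the step that the limit leaves unreadable from compound 3 to compound 4 is expected, resting on the step of a 1.8-fold lower number from compound 1 to compound 2 (0.26 log units; within the scatter) lying within the scatter. Compound 4 is therefore expected to give about 150000 nM, between 50000 nM and 500000 nM, most likely again only as a limit.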

Compound 4, half-maximal inhibitory concentration: 517 nM
Beside the measured number, compound 4's estimate is 290-fold (2.46 log units) above it, outside the stated range (below it).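

In this assay, amino in place of nitro on an aromatic carbon did not carry over from one core to the other, giving an at least 190-fold lower number from compound 3 to compound 4 (2.28 log units; beyond the scatter): the same change on two cores in this assay, a 1.8-fold lower number (0.26 log units; within the scatter) from compound 1 to compound 2 and an at least 190-fold lower number (2.28 log units; beyond the scatter) from compound 3 to compound 4, at least 100-fold (2.02 log units) apart, beyond the scatter of two such steps. Methyl in place of hydrogen on an oxygen also depended on its partner group, giving a 5.6-fold lower number from compound 2 to compound 4 (0.75 log units; beyond the scatter), opposite in direction to the earlier step: the same change on two cores in this assay, an at least 19-fold higher number (1.27 log units; beyond the scatter) from compound 1 to compound 3 and a 5.6-fold lower number (0.75 log units; beyond the scatter) from compound 2 to compound 4, at least 100-fold (2.02 log units) apart, beyond the scatter of two such steps. This shows that, across these four compounds, the effect of either change could not be read from the other core, but it does not show why, and the exact size of both gaps remains unknown since compound 3 rests on an assay limit: the limit of > 100000 nM in this assay, at which 1 of the 4 values shown sits.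

As far as these compounds go, it remains open whether the same dependence would appear with a hydroxyl or an acetamide on that aromatic carbon. From the compounds shown here alone, it is also open whether an ethyl or a longer chain on the oxime oxygen would behave like methyl.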